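The source may hold more compounds than are shown below. What is called first, only, known or untested is meant among the compounds shown, and "the series" means these compounds.

Measured so far in a physicochemical assay for solubility, in phosphate buffer, with a stated time of 18 h; a lower number here means a less soluble compound, a higher number a more soluble compound:
compound 1 `N#Cc1c(N)nc2nc(C3CCCC3)ncc2c1N`: 89000 nM
compound 2 `CC(C)(C)c1ncc2c(N)c(C#N)c(N)nc2n1`: 37200 nM

Compound 2 stands lowest of the two numbers; its nearest neighbour is compound 1, the step being a 2.4-fold lower number from compound 1 to compound 2 (0.38 log units; beyond the scatter). Compound 3 `CC(C)(C)c1nc(-c2cccs2)c2c(N)c(C#N)c(N)nc2n1` differs from compound 2 as follows: thiophen-2-yl in place of hydrogen on an aromatic carbon. Going by the values given here, no measured step bears on this change; the single step so far, a 2.4-fold lower number from compound 1 to compound 2 (0.38 log units; beyond the scatter), exchanges one saturated group for another and says nothing about adding a five-membered aromatic ring. Such an addition of ring atoms is nevertheless expected to move this assay downward, by more than the scatter. Compound 3 is estimated at 5000 nM, between 1000 nM and 25000 nM, a step of a 7.4-fold lower number from compound 2 to compound 3 (0.87 log units; beyond the scatter).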

Compound 3, solubility: 56000 nM
Estimate against measurement, compound 3: 11-fold (1.05 log units) below, and the stated range ends below it.
By their numbers in this assay, from the lowest: compounds 2, 3 and 1 (each within the scatter of the next, the first and the last beyond it).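

In this assay, thiophen-2-yl in place of hydrogen on the aromatic carbon next to the ring nitrogen gives a 1.5-fold higher number from compound 2 to compound 3 (0.18 log units; within the scatter), so at this position five added ring atoms leave the read-out unchanged within the scatter. Going by these compounds alone, this is the first measured step at this carbon, and it adds an aromatic ring rather than exchanging one saturated group for another. No available evidence accounts for this result. As far as these compounds go, whether an amine or a carboxylic acid on this carbon would read the same remains open, as does whether thiophen-2-yl would do so with cyclopentyl in place of tert-butyl.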